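Swapping Fluorine for Chlorine in a Kinase Inhibitor Series

The source may report more compounds than this note shows. Statements on the series, on what has been measured and on what is new or still open speak of the compounds shown alone.

Compound 1 `CC(C)(C)C1=NN(c2cccc(Cl)c2)C(c2ccc(O)cc2)C1` gives 5200 nM in an assay on isolated protein for inhibition of protein kinase C zeta type (Homo sapiens), with a stated time of 4 min; a higher number here means a weaker inhibitor, a lower number a stronger inhibitor.
Compound 2 `CC(C)(C)C1=NN(c2cccc(F)c2)C(c2ccc(O)cc2)C1` gives 2200 nM in this assay.
Compound 3 `CC(C)(C)C1=NN(c2ccc(Cl)cc2)C(c2ccc(O)c(F)c2)C1` gives 3800 nM in this assay.

Compounds 1 and 2 differ in one place only: chloro in place of fluoro on an aromatic carbon. That single change produced a 2.4-fold higher number from compound 2 to compound 1 (0.37 log units; beyond the scatter). Compound 3 differs from compound 2 in more than one place, and the difference between the two cores is not broken down here; its value sits within the scatter of both compound 1 and compound 2.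

Compound 4 `CC(C)(C)C1=NN(c2ccc(Cl)cc2)C(c2ccc(O)c(Cl)c2)C1` is not yet measured. It differs from compound 3 by chloro in place of fluoro on an aromatic carbon. Going by the values given here, this is the same kind of change as the one from compound 2 to compound 1, but not the same: here the place is ortho to a hydroxy group, whereas the earlier place was only meta to a large group. A step of similar direction is expected, a 1.7-fold higher number from compound 3 to compound 4 (0.23 log units; within the scatter), and that expectation rests on compound 2 to compound 1 showing a 2.4-fold higher number from compound 2 to compound 1 (0.37 log units; beyond the scatter). Compound 4 is therefore estimated at 6500 nM, with a range from 2500 nM to 16000 nM.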

Compound 4, half-maximal inhibitory concentration: 700 nM
Beside the measured number, compound 4's estimate is 9.3-fold (0.97 log units) above it; the whole stated range lies above it.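

Putting chloro in place of fluoro, so that 3-fluoro-4-hydroxyphenyl becomes 3-chloro-4-hydroxyphenyl, gave a 5.4-fold lower number from compound 3 to compound 4 (0.73 log units; beyond the scatter) in this assay, which here means stronger inhibition. Going by these compounds alone, the same swap on the other core went the opposite way, so it cannot be carried from one core to another with a fixed size, or even a fixed direction: the same change on two cores in this assay, a 2.4-fold higher number (0.37 log units; beyond the scatter) from compound 2 to compound 1 and a 5.4-fold lower number (0.73 log units; beyond the scatter) from compound 3 to compound 4, 13-fold (1.11 log units) apart, beyond the scatter of two such steps What this does not show is the reason for the reversal, since only two pairs are at hand and they differ both in the rest of the core and in the place of the swap, which is ortho to a hydroxy group only in the newer pair.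

The compounds shown leave open whether the gain depends on that hydroxy group, since all of them carry it, and a methoxy group or an amine in its place would test this. As far as these compounds go, it is also open whether bromo at the same place would behave like chloro.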